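Swapping the aryl group on a trifluoroacetyl thiophene series

The source may report more compounds than this note shows. Statements on the series, on what has been measured and on what is new or still open speak of the compounds shown alone.

Measured so far:
compound 1, `O=C(c1ccc(-c2nnc(-c3ccccc3)o2)s1)C(F)(F)F`, 330 nM
compound 2, `O=C(c1ccc(-c2nc(-c3ccc(Cl)cc3Cl)no2)s1)C(F)(F)F`, 3000 nM
compound 3, `O=C(c1ccc(-c2nc(CS(=O)(=O)c3cccs3)no2)s1)C(F)(F)F`, 520 nM

All three were tested in an assay on isolated protein for inhibition of protein deacetylase HDAC6 (Homo sapiens); a lower number here means a stronger inhibitor, a higher number a weaker inhibitor. Among them compound 2 gives the highest number, so it is the weakest inhibitor of the three, beyond the scatter against both compound 1 and compound 3. Compound 4, `Cc1cccc(-c2noc(-c3ccc(C(=O)C(F)(F)F)s3)n2)c1`, has not yet been measured. It differs from compound 2 in one place: 3-methylphenyl in place of 2,4-dichlorophenyl on an aromatic carbon. The 3-methylphenyl group of compound 4 resembles the plain phenyl of compound 1 more closely than the 2,4-dichlorophenyl of compound 2 does, and compound 1 gives a far lower number. An improvement is therefore expected, of the size a 3.3-fold lower number from compound 2 to compound 4 (0.52 log units; beyond the scatter). Compound 4 is estimated at 900 nM, within 300 nM to 2700 nM.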

Compound 4, half-maximal inhibitory concentration: 680 nM
Beside the measured number, compound 4's estimate is 1.3-fold (0.12 log units) above it, and the stated range covers the measured number.
By their numbers in this assay, from the lowest: compounds 1, 3 and 4 (each within the scatter of the next, the first and the last beyond it); then compound 2.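

Putting 3-methylphenyl in place of 2,4-dichlorophenyl on the same aromatic carbon gives a 4.4-fold lower number from compound 2 to compound 4 (0.64 log units; beyond the scatter) in this assay. This first one-place comparison shows that the aryl group at this position can by itself move the number beyond the scatter. No measured property bears on this result.

The compounds shown leave open whether the loss of the two chlorine atoms or the gain of the methyl accounts for the step. They also leave open how an amine or a carboxylic acid on this phenyl ring would fare.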